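Adding a Third Fluoro Group to Compound 3

A few compounds are considered here, and "the series" means these few. Any claim that something is new, unique, unknown or untested is made for them only; others in the source may bear on it.

Of the compounds shown here, three sharing one core have been measured in a functional assay on A549 cells (Homo sapiens) for cytotoxicity, read by MTT assay, with a stated time of 48 h; a lower number here means a stronger inhibitor, a higher number a weaker inhibitor. Compound 1 `Cc1ccc(S(=O)(=O)/N=C(/CCNC2=CC(=O)c3ccccc3C2=O)Nc2ccc(F)cc2)cc1` gives 9330 nM, compound 2 `Cc1ccc(S(=O)(=O)/N=C(/CCNC2=CC(=O)c3ccccc3C2=O)Nc2ccccc2I)cc1` gives 24700 nM, and compound 3 `Cc1ccc(S(=O)(=O)/N=C(/CCNC2=CC(=O)c3ccccc3C2=O)Nc2ccc(F)c(F)c2)cc1` gives 16700 nM. Compound 3 thus holds the second highest of the three numbers, separated from compound 2 by a 1.5-fold lower number from compound 2 to compound 3 (0.17 log units; within the scatter) and from compound 1 by a 1.8-fold higher number from compound 1 to compound 3 (0.25 log units; within the scatter), both within the scatter. Compound 4 `Cc1ccc(S(=O)(=O)/N=C(/CCNC2=CC(=O)c3ccccc3C2=O)Nc2cc(F)c(F)c(F)c2)cc1` differs from compound 3 by fluoro in place of hydrogen on an aromatic carbon. Among the measured compounds shown here, the only measured step of the same kind, a 1.8-fold higher number from compound 1 to compound 3 (0.25 log units; within the scatter), stayed within the scatter, so a further fluoro group is expected to move the number little, perhaps slightly upward, as a 1.3-fold higher number from compound 3 to compound 4 (0.12 log units; within the scatter). Compound 4 is therefore estimated at 22000 nM, with a range from 9000 nM to 55000 nM.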

Compound 4, half-maximal inhibitory concentration: 10200 nM
The estimate for compound 4 lay 2.2-fold (0.33 log units) above the measured number; the measured number falls inside the stated range.
By their numbers in this assay, from the lowest: compounds 1, 4, 3 and 2 (each within the scatter of the next, the first and the last beyond it).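

In this assay the added fluoro group gives a 1.6-fold lower number from compound 3 to compound 4 (0.21 log units; within the scatter) and the trifluorophenyl ring compared with the 4-fluorophenyl ring gives a 1.1-fold higher number from compound 1 to compound 4 (0.04 log units; within the scatter), both within the scatter, so compounds 1, 3 and 4 cannot be told apart. Only the 2-iodophenyl comparison passes the scatter, with a 2.4-fold lower number from compound 2 to compound 4 (0.38 log units; beyond the scatter) as a modest step. No measurement shown here offers an explanation for these numbers. As far as these compounds go, whether a methoxy group or an amine in place of this new fluoro group would move the number beyond the scatter stays open.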